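A few compounds are considered here, and "the series" means these few. Any claim that something is new, unique, unknown or untested is made for them only; others in the source may bear on it.

Measured so far in a functional assay for inhibition, with Homo sapiens as the target; a higher number here means a weaker inhibitor, a lower number a stronger inhibitor:
- compound 1 `Cc1ccc(-c2ccnc(Nc3cccc(N(C)C)c3)n2)s1` gives 5700 nM
- compound 2 `COc1cccc(Nc2nccc(-c3ccc(C)o3)n2)c1` gives 1500 nM
- compound 3 `COc1cccc(Nc2nccc(-c3cc4ccccc4o3)n2)c1` gives 2800 nM

Within this small set compound 1 stands at the highest number, that is, as the weakest inhibitor of the three. Its nearest neighbour by number is compound 3, and the gap between them lies beyond the usual scatter; compound 2 sits further off still, also beyond the scatter. Going by the values given here, no pair among the three differs in a single place, so no single-change step can be read from the measured compounds: compound 2 and compound 3 carry a different group on the aniline as well as a different aryl group on the shared core.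

Compound 4 `CN(C)c1cccc(Nc2nccc(-c3ccccn3)n2)c1` is the next member to be measured. It keeps the aniline of compound 1 and changes only the aryl group: pyridin-2-yl in place of 5-methylthiophen-2-yl on an aromatic carbon

Among the compounds with values here, no measured step with this change exists, and the two other compounds cannot separate the aryl exchange from the aniline exchange. For compound 4 the expectation in this assay is therefore centred near compound 1, at 4500 nM, with a range from 1200 nM to 15000 nM. The step of a 1.3-fold lower number from compound 1 to compound 4 (0.10 log units; within the scatter) is expected to be small, with no clear direction beyond the scatter.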

Compound 4, half-maximal inhibitory concentration: 400 nM
Beside the measured number, compound 4's estimate is 11-fold (1.05 log units) above it; the whole stated range lies above it.
By their numbers in this assay, from the lowest: compound 4; then compounds 2 and 3 (each within the scatter of the next); then compound 1.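

In this assay, the aryl group on the shared core turns out to be a sensitive position: with the dimethylamino aniline held constant, pyridin-2-yl in place of 5-methylthiophen-2-yl gives a 14-fold lower number from compound 1 to compound 4 (1.15 log units; beyond the scatter), a large step. The earlier compounds shown here could not show this, as none of them differed from another in one place, so the aryl exchange could not be separated from the aniline exchange. The groups that leave and enter match in heavy atoms, hydrogen-bond donors and hydrogen-bond acceptors, so these counts do not distinguish them, and nothing at hand bears on why the step is this large.

Still open, from the compounds shown here alone, is which part of the exchange carries the step, the ring size, the ring nitrogen in place of sulfur or the loss of the methyl; an unsubstituted thiophen-2-yl, a phenyl or a pyridin-3-yl at this place would help to separate these. Also open, going by these compounds, is whether pyridin-2-yl gives a similar step on the methoxy aniline carried by compound 2 and compound 3.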